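Aryl-Piperazine Dithiocarbamate Benzamides: Toward a Methylphenyl Analogue

This account rests on a few compounds, and the source may have more. Where it says the series, first, only, none or still open, it means among the compounds named here.

Of the compounds shown here, three sharing one core have been measured in a functional assay on A-375 cells (Homo sapiens) for antiproliferative activity, read by CCK-8 assay, with a stated time of 72 h, tested at 2 uM; on this read-out lower numbers stand for a weaker effect and higher numbers for a stronger effect at the one concentration tested. Compound 1 `Nc1ccccc1NC(=O)c1ccc(CSC(=S)N2CCN(Cc3ccccc3)CC2)cc1` gives 10.6% in this assay. Compound 2 `Nc1ccccc1NC(=O)c1ccc(CSC(=S)N2CCN(c3cnccn3)CC2)cc1` gives 29.1%, and compound 3 `Nc1ccccc1NC(=O)c1ccc(CSC(=S)N2CCN(Cc3cccnc3)CC2)cc1` gives 31.5%. Compound 3 thus stands highest of the three numbers, though its gap to compound 2 lies within the scatter, while its gap to compound 1 lies beyond it, as seen in a number 20.9 percentage points higher from compound 1 to compound 3 (beyond the scatter).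

Compound 4 `Cc1ccc(N2CCN(C(=S)SCc3ccc(C(=O)Nc4ccccc4N)cc3)CC2)cc1` differs from compound 3 in one place: 4-methylphenyl in place of (pyridin-3-yl)methyl on an amine nitrogen in a ring. Within the data shown here, two measured steps bear on this. The step of a number 18.5 percentage points higher from compound 1 to compound 2 (beyond the scatter) and the step of a number 20.9 percentage points higher from compound 1 to compound 3 (beyond the scatter) both moved the number upward when a ring with a nitrogen atom replaced a carbon-only ring on the piperazine nitrogen, whether bonded directly or through a carbon. The step of a number 2.4 percentage points higher from compound 2 to compound 3 (within the scatter) shows that direct versus one-carbon attachment made no difference beyond the scatter. Compound 4 returns to a carbon-only ring, so the account expects a downward step of a number 14.5 percentage points lower from compound 3 to compound 4 (beyond the scatter), toward the level of compound 1. Compound 4 is therefore estimated at 17%, with a range from 7% to 32%.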

Compound 4, a percentage reported as inhibition, at one concentration (the size of the read-out at that concentration, not a potency): 25.8%
The estimate for compound 4 lay 8.8 percentage points below the measured number, and the stated range covers the measured number.
By their numbers in this assay, from the lowest: compound 1; then compounds 4, 2 and 3 (each within the scatter of the next).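

In this assay, a carbon-only ring on the amine nitrogen in the ring does not by itself separate a compound from those bearing a nitrogen-containing ring: 4-methylphenyl in place of (pyridin-3-yl)methyl gives a number 5.7 percentage points lower from compound 3 to compound 4 (within the scatter), and in place of pyrazin-2-yl it gives a number 3.3 percentage points lower from compound 2 to compound 4 (within the scatter). The low number thus belongs to compound 1 alone among the four and not to carbon-only rings as a class, as 4-methylphenyl in place of benzyl gives a number 15.2 percentage points higher from compound 1 to compound 4 (beyond the scatter). Nothing measured on these compounds accounts for this difference between the two carbon-only groups.

Compound 4 differs from compound 1 both in its methyl group and in the absence of the one-carbon link, so the two changes cannot be told apart here. An unsubstituted phenyl group on this nitrogen would be needed to separate them.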